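Methoxy for chloro on the aryl ether of compound 2

A few compounds are considered here, and "the series" means these few. Any claim that something is new, unique, unknown or untested is made for them only; others in the source may bear on it.

The shared core carries a spiro ring fused to a diaminotriazine, linked through an oxygen and a three-carbon chain to an aryl ether. Compound 1 `NC1=NC2(CCOCC2)N(OCCCOc2cc(Cl)c(Cl)cc2Cl)C(N)=N1` bears a trichlorophenyl ether and an oxa-containing spiro ring; in a functional assay on MDA-MB-231 cells (Homo sapiens) for antiproliferative activity, read by MTT assay, with a stated time of 72 h (on this read-out lower numbers stand for stronger inhibition and higher numbers for weaker inhibition), compound 1 is recorded as "not determined" (no result reported). Compound 2 `NC1=NC2(CCSCC2)N(OCCCOc2ccc(Cl)cc2)C(N)=N1` has the thia-containing spiro ring and a 4-chlorophenyl ether, and in this assay compound 2 gives 350 nM. Compound 3 `NC1=NC2(CCOCC2)N(OCCCOc2cccc(Br)c2)C(N)=N1`, with the oxa ring and a 3-bromophenyl ether, gives 400 nM in this assay. Compound 2 holds the lowest of the two numbers reported, yet its gap to compound 3 lies within the scatter, so the two cannot be ordered.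

Compound 4 `COc1ccc(OCCCON2C(N)=NC(N)=NC23CCSCC3)cc1` differs from compound 2 in one place: methoxy in place of chloro on an aromatic carbon. Among the measured compounds shown here, no measured pair shows this exact change, so its effect is unknown from the data at hand. Trading a halogen for a methoxy on the aryl ether is expected to cost some potency, a step somewhat beyond the scatter. Compound 4 is therefore estimated at 800 nM, within a range from 300 nM to 2500 nM, which means an expected step of a 2.3-fold higher number from compound 2 to compound 4 (0.36 log units; beyond the scatter).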

Compound 4, half-maximal inhibitory concentration: 350 nM
Estimate against measurement, compound 4: 2.3-fold (0.36 log units) above, and the stated range covers the measured number.
By their numbers in this assay, from the lowest: compounds 2, 4 and 3 (each within the scatter of the next).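

In this assay, among the compounds shown here, the change from 4-chlorophenyl to 4-methoxyphenyl gives no change at the digits printed from compound 2 to compound 4 (within the scatter) and is the first step in this set that isolates a single place, since the earlier compounds differ from one another in more than one. At this aromatic carbon, para to a large group, the read-out therefore accepts two heavy atoms and one hydrogen-bond acceptor in place of a single chlorine without a change that can be told from the scatter. No measurement at hand explains why the two groups read alike.

The compounds shown leave open whether this tolerance extends to quite different groups at the same place, such as an amine, a carboxylic acid or a nitrile, and whether it would hold with a longer chain between the shared core and the aryl ether. They also leave open what the sulfur-containing spiro ring contributes by comparison with the oxygen-containing one, as compound 3 differs from compound 2 in both the ring and the halogen on the aryl ether.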